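Shortening the chain in the series

The compounds below may be only part of what the source reports. "The series", "measured", "known", "first", "only" and "open" are said of these compounds alone.

Measured in a functional assay on HCT-116 cells (Homo sapiens) for cytotoxicity, read by sulforhodamine B assay; a higher number here means that more compound is needed for the effect, a lower number that less compound is needed:
compound 1 `CCCCCCCCCCCCC/C=C/[C@@H](O)[C@H](CO)n1cc(CCCCCCCCCCCCC)nn1` gives > 50000 nM (a limit)
compound 2 `CCCCCCCCCCCCC/C=C/[C@@H](O)[C@H](CO)n1cc(CCCCCCCCCCCCCCCCCCCCCCCC)nn1` gives > 50000 nM (a limit)

Not yet measured: compound 3 `CCCCCCCCCCCCC/C=C/[C@@H](O)[C@H](CO)n1cc(CCCC)nn1`

Compound 1 has no number here and stands at the limit of > 50000 nM in this assay, at which 2 of the 2 values shown sit (shared with compound 2). The change to compound 3 is hydrogen in place of nonyl on a saturated chain carbon, four bonds along the chain from an aromatic carbon. Going by the values given here, the only measured step is a step that the two limits leave unreadable from compound 1 to compound 2 (undecyl in place of hydrogen) and it gives no size to carry over. Only a move to lower concentration could be read from this limit, so a modest step in that direction is expected, though compound 3 may well stay at the limit. The estimated step is an at least 2.0-fold lower number from compound 1 to compound 3 (0.30 log units; that floor lies within the scatter) (an expectation only). For compound 3 the expected value is 25000 nM (estimated range 10000 nM to 50000 nM) and it remains to be measured.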

Compound 3, half-maximal effective concentration: 12900 nM
Compound 3: middle estimate off by 1.9-fold (0.29 log units), on the high side; low and high end bracket the measured number.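

Hydrogen in place of nonyl, on a saturated chain carbon four bonds along the chain from an aromatic carbon, gives the only readable move in this assay: an at least 3.8-fold lower number from compound 1 to compound 3 (0.58 log units; beyond the scatter). The size of this step is a floor, since the value of compound 1 is a limit. The step from compound 1 to compound 2 cannot be read, and the chain only shows an effect once it is shortened, as compound 3 leaves the limit shared by the other two: the limit of > 50000 nM in this assay, at which 2 of the 3 values shown sit.

Open, from the compounds shown here alone, is whether a chain shorter still, such as ethyl, would lower the number further. Also open, going by these compounds, is how an amine or a carboxylic acid on this chain would read.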